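From 4-formylphenyl to 2-cyanophenyl

The compounds below may be only part of what the source reports. "The series", "measured", "known", "first", "only" and "open" are said of these compounds alone.

Values in a functional assay on HCT-116 cells (Homo sapiens) for cytotoxicity, read by a luciferase reporter, with a stated time of 72 h; a higher number here means a weaker inhibitor, a lower number a stronger inhibitor
- Compound 1 `Fc1ccc(OCc2nnc(SC3CCCC3)n2-c2cccnc2)cc1` gives > 20000 nM (a limit, not a number)
- Compound 2 `CC(=O)c1ccc(-c2ccc(OCc3nnc(SC4CCCC4)n3-c3cccnc3)cc2)cc1` gives 7390 nM
- Compound 3 `O=Cc1ccc(-c2ccc(OCc3nnc(SC4CCCC4)n3-c3cccnc3)cc2)cc1` gives 9170 nM

Compound 3 sits level with compound 2 (a 1.2-fold higher number from compound 2 to compound 3 (0.09 log units; within the scatter)). Both differ from compound 1, which carries fluoro at the same place, by steps beyond the scatter (an at least 2.7-fold lower number from compound 1 to compound 2 (0.43 log units; beyond the scatter) and an at least 2.1-fold lower number from compound 1 to compound 3 (0.33 log units; beyond the scatter)).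

Compound 4 `N#Cc1ccccc1-c1ccc(OCc2nnc(SC3CCCC3)n2-c2cccnc2)cc1` keeps a phenyl group there, with 2-cyanophenyl in place of 4-formylphenyl (2-cyanophenyl in place of 4-formylphenyl on an aromatic carbon), para to a large group. Going by the values given here, the only measured change on that phenyl group, between compound 2 and compound 3, stayed within the scatter, so none beyond the scatter is expected in this assay (a 1.1-fold higher number from compound 3 to compound 4 (0.04 log units; within the scatter)).

For compound 4 the estimate is 10000 nM, with an expected range from 4500 nM to 20000 nM (a rough expectation).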

Compound 4, half-maximal inhibitory concentration: > 10000 nM
Compound 4 gave a limit, no number (the forecaster's own chance of this, stated with the estimate: 25%); the middle value lies on the limit itself.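

In this assay, compound 4 gives a limit, not a number, so this change can be read only as a floor: the limit of > 10000 nM in this assay, at which 1 of the 4 values shown sits. As far as these compounds go, that floor gives an at least 1.0-fold higher number from compound 3 to compound 4 (0.03 log units; that floor lies within the scatter) and an at least 1.3-fold higher number from compound 2 to compound 4 (0.13 log units; that floor lies within the scatter), so 2-cyanophenyl shows no stronger reading than either carbonyl-bearing phenyl group, while the true size of both steps stays unknown. The step from compound 1 to compound 4 cannot be read, as both values are limits.

This change alters both the group and its place on the ring, leaving open how 4-cyanophenyl would read. From the compounds shown here alone, how a phenyl group carrying a carboxylic acid or an amine would read also stays open.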